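Swapping a Pentyl Chain for a Pentylphenyl Ring

The source may hold more compounds than are shown below. What is called first, only, known or untested is meant among the compounds shown, and "the series" means these compounds.

Compound 1, `CCCCCCC#Cc1cn(C/C=C/CN2C(=O)c3ccccc3C2=O)c(=O)[nH]c1=O`, gives 43000 nM in a functional assay on L1210 cells (Mus musculus) for antiproliferative activity, read by MTT assay, with a stated time of 2 days; a higher number here means a weaker inhibitor, a lower number a stronger inhibitor.
Compound 2, `CCCCCC#Cc1cn(C/C=C/CN2C(=O)c3ccccc3C2=O)c(=O)[nH]c1=O`, gives > 500000 nM in this assay; this is a limit of the assay, not a number.

Within the data shown here, compound 2 therefore sits at the limit of > 500000 nM in this assay, at which 1 of the 2 values shown sits, and only one of the two values is a true number. Among the measured compounds shown here, the single measured step, an at least 11-fold higher number from compound 1 to compound 2 (1.06 log units; beyond the scatter), shows that taking one chain carbon away made the inhibitor much weaker. Compound 3, `CCCCCc1ccc(C#Cc2cn(C/C=C/CN3C(=O)c4ccccc4C3=O)c(=O)[nH]c2=O)cc1`, carries 4-pentylphenyl in place of pentyl on a triple-bonded carbon. This adds carbons and a ring rather than removing them, so, given an at least 11-fold higher number from compound 1 to compound 2 (1.06 log units; beyond the scatter), compound 3 is expected to be stronger than compound 2, though the size is uncertain. For compound 3 the estimated value is 100000 nM, within 20000 nM to 500000 nM, an expected at least 5.0-fold lower number from compound 2 to compound 3 (0.69 log units; beyond the scatter).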

Compound 3, half-maximal inhibitory concentration: 39000 nM
Compound 3: middle estimate off by 2.6-fold (0.41 log units), on the high side; low and high end bracket the measured number.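

Putting 4-pentylphenyl in place of pentyl on the triple-bonded carbon gives an at least 12-fold lower number from compound 2 to compound 3 (1.10 log units; beyond the scatter), so this position accepts an aromatic ring as well as a plain chain. Set against the hexyl chain, the same group gives a 1.1-fold lower number from compound 1 to compound 3 (0.04 log units; within the scatter), so compound 1 and compound 3 cannot be told apart here. The size of the first step is only a bound, as the value for compound 2 is a limit: the limit of > 500000 nM in this assay, at which 1 of the 3 values shown sits.

From the compounds shown here alone, whether the ring or its pentyl tail matters more stays open. A bare phenyl group or a longer chain such as octyl could help separate the two.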